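The compounds below may be only part of what the source reports. "The series", "measured", "known", "first", "only" and "open" are said of these compounds alone.

Working notes on the series. Compound 1 `Cc1ncc(-c2nc(C(F)(F)F)sc2N2CCN(C(=O)Cn3cnc4cccnc43)[C@H](C)C2)cn1` gives 168 nM in a functional assay on U2OS cells for antagonist activity at C-X-C chemokine receptor type 3 (Homo sapiens), read by beta-arrestin recruitment; on this read-out lower numbers stand for stronger inhibition and higher numbers for weaker inhibition. For the measured compounds named here, compound 2 `Cc1ncc(-c2nc(C(F)(F)F)sc2N2CCN(C(=O)Cn3nc(C)nc3C)[C@H](C)C2)cn1` gives 578 nM in this assay, the highest of the two numbers so far; the exchange on the saturated chain carbon bound to the carbonyl carbon gave a 3.4-fold higher number from compound 1 to compound 2 (0.54 log units; beyond the scatter). Compound 3 `Cc1nc(C)n(CC(=O)N2CCN(c3sc(C(F)(F)F)nc3-c3cnc(C(C)(C)C)nc3)C[C@H]2C)n1` carries tert-butyl in place of methyl on an aromatic carbon. Going by the values given here, no measured step touches this position: the only step in hand, from compound 1 to compound 2, concerns a different part of the molecule, so nothing here sets size or direction for the move. For compound 3 the expected step is a 1.0-fold higher number from compound 2 to compound 3 (0.02 log units; within the scatter), within the scatter. For compound 3 in this assay the estimate is 600 nM, with a range from 200 nM to 1800 nM.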

Compound 3, half-maximal inhibitory concentration: 1030 nM
Compound 3: the middle estimate sits 1.7-fold (0.23 log units) below what was measured; measured number inside the range.
By their numbers in this assay, from the lowest: compound 1; then compounds 2 and 3 (each within the scatter of the next).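

Exchanging methyl for tert-butyl on the aromatic carbon between two ring nitrogen atoms gives a 1.8-fold higher number from compound 2 to compound 3 (0.25 log units; within the scatter). This position therefore carries both groups, with the added carbons of tert-butyl, and compound 2 and compound 3 cannot be separated by their numbers. No evidence on hand bears on this result.

On these data alone, whether an amine or a carboxylic acid at this position would read the same stays open. Also open, as far as these compounds go, is whether tert-butyl reads the same on the amide side chain of compound 1.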